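An Unmeasured Ring Swap Judged from a Limit

The source may report more compounds than this note shows. Statements on the series, on what has been measured and on what is new or still open speak of the compounds shown alone.

Two compounds were examined in a functional assay on the whole organism for inhibition, with Rattus norvegicus as the target, read by paw edema; on this read-out higher numbers stand for an effect only at larger amounts of compound and lower numbers for an effect already at smaller amounts. Compound 1, `O=C(O)c1cc(-c2cncs2)ccc1O`, reached only a limit in this assay, > 200 mg/kg. Compound 2, `O=C(O)c1ccc(-c2nccs2)cc1O`, gave in this assay 110 mg/kg. For the measured compounds named here, no pair of measured compounds differs in one place, so no measured step can be drawn; the two values show only that compound 2 produced a number where compound 1 did not.

Compound 3, `O=C(O)c1cc(-c2ccns2)ccc1O`, has not yet been measured. It differs from compound 1 by 1,2-thiazol-5-yl in place of 1,3-thiazol-5-yl on an aromatic carbon. Going by the values given here, with compound 1 resting on a limit (the limit of > 200 mg/kg in this assay, at which 1 of the 2 values shown sits), the starting point is itself uncertain, and no measured step of this kind exists to set a size. The expectation is that the step of a number no higher from compound 1 to compound 3 (the limit leaves the size open) stays within the scatter, with no direction beyond it. Compound 3 is therefore estimated at 200 mg/kg, within 100 mg/kg to 400 mg/kg, and a further limit is quite possible.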

Compound 3, dose for half-maximal effect: 80 mg/kg
The estimate for compound 3 lay 2.5-fold (0.40 log units) above the measured number; the measured number lies below the stated range.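

At the position meta to the carboxy group and para to the hydroxy group, 1,2-thiazol-5-yl in place of 1,3-thiazol-5-yl gives an at least 2.5-fold lower number from compound 1 to compound 3 (0.39 log units; beyond the scatter) in this assay. For the compounds shown here, this is the first measured step at this place, and it shows that the read-out responds to how the same atoms are joined within the five-membered aromatic ring, since the two groups match in every property counted. The true size of the step remains open because compound 1 rests on a limit: the limit of > 200 mg/kg in this assay, at which 1 of the 3 values shown sits.

Going by these compounds, whether a thiophene, a furan or a simple amine at this place would give a similar number remains open. Compound 2 differs from compound 3 in more than one place, so it cannot show whether the step carries over to another arrangement of the shared groups.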